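Growth inhibition in rapeseed: swapping methoxy for chloro

The source may hold more compounds than are shown below. What is called first, only, known or untested is meant among the compounds shown, and "the series" means these compounds.

Measured so far:
compound 1 `Cc1onc(-c2ccc(Cl)cc2Cl)c1C(=O)/N=c1/nc2nc(Cl)cc(C)n2s1`: 20.1%
compound 2 `COc1cc(OC)n2s/c(=N\C(=O)c3c(-c4ccc(Cl)cc4Cl)noc3C)nc2n1`: 49.3%

In a functional assay on the whole organism for inhibition, with Brassica napus as the target, with a stated time of 72 h, tested at 10 mg/L (a lower number here means less inhibition of growth, a higher number more inhibition of growth at the concentration tested), compound 2 stands highest of the two numbers; the gap to compound 1 lies beyond the usual scatter. Compound 3 `COc1cc(Cl)nc2n/c(=N/C(=O)c3c(-c4ccc(Cl)cc4Cl)noc3C)sn12` is not yet measured. It differs from compound 2 by chloro in place of methoxy on an aromatic carbon. Among the measured compounds shown here, no pair of measured compounds shows this exact step, so its size must be guessed. A drop is expected because compound 1 with its own chloro group gives 20.1%. Compound 3 is expected at 34%, within 15% to 55%. The expected step is a number 15.3 percentage points lower from compound 2 to compound 3 (beyond the scatter).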

Compound 3, percent growth inhibition at one concentration: 28.6%
Beside the measured number, compound 3's estimate is 5.4 percentage points above it; the range from low to high includes it.
By their numbers in this assay, from the lowest: compounds 1 and 3 (each within the scatter of the next); then compound 2.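

In this assay, chloro in place of methoxy on an aromatic carbon gives a number 20.7 percentage points lower from compound 2 to compound 3 (beyond the scatter) and so, on its own, is enough to lower growth inhibition. With that chloro present, methoxy in place of methyl on an aromatic carbon gives a number 8.5 percentage points higher from compound 1 to compound 3 (within the scatter) and so makes no clear difference. No measurement here explains why the first change matters. On these data alone, whether an amine or an ethoxy group on that aromatic carbon would match methoxy remains open, as does whether methoxy is needed on both carbons.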